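The compounds below may be only part of what the source reports. "The series", "measured", "known", "first", "only" and "open" are said of these compounds alone.

Measured so far in an ADME assay on microsomes from liver (Homo sapiens) for pharmacokinetics, read by LC-MS, with a stated time of 60 min, tested at 1 uM (on this read-out lower numbers stand for slow clearance and higher numbers for fast clearance), are three compounds.
- Compound 1 `O=C(NCc1ccc(S(=O)(=O)c2ccccc2)cc1)N1Cc2ccncc2C1` gives 7.5 mL/min/kg
- Compound 2 `O=C(NCc1ccc(S(=O)(=O)c2cc(F)cc(F)c2)cc1)N1Cc2ccncc2C1` gives 8 mL/min/kg
- Compound 3 `CCCn1cc(S(=O)(=O)c2ccc(CNC(=O)N3Cc4ccncc4C3)cc2)cn1` gives 11 mL/min/kg

Compound 3 lies within the scatter of both other compounds, as a 1.5-fold higher number from compound 1 to compound 3 (0.17 log units; within the scatter) and a 1.4-fold higher number from compound 2 to compound 3 (0.14 log units; within the scatter) show. Compound 4 `CC(C)n1cc(S(=O)(=O)c2ccc(CNC(=O)N3Cc4ccncc4C3)cc2)cn1` differs from compound 3 in one place (isopropyl in place of propyl on an aromatic nitrogen), with isopropyl in place of propyl on an aromatic nitrogen. Among the compounds with values here, no measured pair varies that propyl. The nearest evidence is exchange of the whole group on the sulfonyl sulfur, where a 1.5-fold higher number from compound 1 to compound 3 (0.17 log units; within the scatter) and a 1.4-fold higher number from compound 2 to compound 3 (0.14 log units; within the scatter) both stayed within the scatter, as did a 1.1-fold higher number from compound 1 to compound 2 (0.03 log units; within the scatter) on the other exchange. The expected change, a 1.1-fold lower number from compound 3 to compound 4 (0.04 log units; within the scatter), is therefore none beyond the scatter, with no firm direction. For compound 4 the estimate is 10 mL/min/kg, with an expected range from 6 mL/min/kg to 17 mL/min/kg at most.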

Compound 4, clearance: 4 mL/min/kg
The estimate for compound 4 lay 2.5-fold (0.40 log units) above the measured number; the whole stated range lies above it.
By their numbers in this assay, from the lowest: compounds 4, 1, 2 and 3 (each within the scatter of the next, the first and the last beyond it).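

Changing propyl to isopropyl on an aromatic nitrogen, with the same atoms joined differently, gives a 2.8-fold lower number from compound 3 to compound 4 (0.44 log units; beyond the scatter) in this assay and is the only step among these compounds beyond the scatter for a single change at this position. Exchanging the whole group on the sulfonyl sulfur stays within the scatter, both in a 2.0-fold lower number from compound 2 to compound 4 (0.30 log units; within the scatter) and in a 1.9-fold lower number from compound 1 to compound 4 (0.27 log units; within the scatter) by the printed steps. Nothing measured here accounts for the step from propyl to isopropyl. Going by these compounds, whether cyclopropyl or tert-butyl on that nitrogen would follow isopropyl stays open. So does whether the step holds with another group in place of the urea.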